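Phenylsulfanyl in place of methylamino: a forward estimate

This account rests on a few compounds, and the source may have more. Where it says the series, first, only, none or still open, it means among the compounds named here.

Compound 2 `CNC1=C(Sc2ccccc2)C(=O)c2cccnc2C1=O` and compound 1 `CNC1=C(Sc2ccccc2)C(=O)c2ncccc2C1=O` share the same core and differ only in where the ring nitrogen sits. In a functional assay on cells (Neutrophil, Homo sapiens) for inhibition, read by WST assay, with a stated time of 20 min (on this read-out higher numbers stand for weaker inhibition and lower numbers for stronger inhibition), compound 2 gives 92800 nM. Compound 1 in this assay returns only a limit, > 150000 nM. Going by the values given here, compound 2 therefore holds the only number in the set, the other entry being a limit, (the limit of > 150000 nM in this assay, at which 1 of the 2 values shown sits), so there is nothing to rank compound 2 against.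

Compound 3 `O=C1C(Sc2ccccc2)=C(Sc2ccccc2)C(=O)c2ncccc21` is compound 2 with phenylsulfanyl in place of methylamino on a double-bonded ring carbon. Among the compounds with values here, no measured step of this kind exists in the set, so the direction in this assay cannot be read from the data. With both ring positions now carrying phenylsulfanyl, the expected step is a 1.5-fold lower number from compound 2 to compound 3 (0.19 log units; within the scatter) in this assay, held modest because compound 2 itself only reaches 92800 nM. Compound 3 is thus expected to give 60000 nM in this assay, with a range from 15000 nM to 200000 nM, and a fair chance that only a limit is returned.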

Compound 3, half-maximal inhibitory concentration: 24800 nM
Estimate against measurement, compound 3: 2.4-fold (0.38 log units) above, and the stated range covers the measured number.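

In this assay, going by these compounds alone, phenylsulfanyl in place of methylamino on a double-bonded ring carbon gives the first measured change at this position, and its size lies beyond the scatter: a 3.7-fold lower number from compound 2 to compound 3 (0.57 log units; beyond the scatter). The same change also gives an at least 6.0-fold lower number from compound 1 to compound 3 (0.78 log units; beyond the scatter), so the number falls from both compounds that carry methylamino, whichever place their ring nitrogen takes, and the hydrogen-bond donor of methylamino is not required for the lower number seen here. For compound 1 the starting point of that second step is a limit and not a number, so its size is only a bound: the limit of > 150000 nM in this assay, at which 1 of the 3 values shown sits.

The compounds shown leave open whether the fall follows the sulfur, the aromatic ring of the entering group or the departure of methylamino, and methylsulfanyl or phenoxy on this carbon would begin to separate these. They also leave open whether a single phenylsulfanyl paired with a group such as dimethylamino would be enough, given that compound 3, at 24800 nM, carries phenylsulfanyl on both double-bonded ring carbons.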